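A Nitro Group Enters Where Methoxyphenyl Stood

The compounds below may be only part of what the source reports. "The series", "measured", "known", "first", "only" and "open" are said of these compounds alone.

Of the compounds shown here, three built on one shared core have been measured in a functional assay on HepG2 cells (Homo sapiens) for antiproliferative activity, tested at 1 uM; on this read-out higher numbers stand for more inhibition at the one concentration tested (going by the name of the read-out) and lower numbers for less inhibition. Compound 1 `Cc1nn(C)c(Oc2ccccc2)c1/C=N/OCc1ccc(C(F)(F)F)cc1` gives 5.8% in this assay. Compound 2 `Cc1nn(C)c(Oc2ccc(Cl)cc2)c1/C=N/OCc1ccc([N+](=O)[O-])cc1` gives 18.4%. Compound 3 `COc1cccc(CO/N=C/c2c(C)nn(C)c2Oc2ccccc2)c1` gives -41.2%, the lowest of the three numbers: its nearest neighbour is compound 1, which lies higher by a margin beyond the usual scatter, and compound 2 lies further away still, also beyond the scatter. Among the measured compounds shown here, no two of the measured compounds differ in only one place, so no single step between measured compounds can be read off.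

Compound 4 `Cc1nn(C)c(Oc2ccccc2)c1/C=N/OCc1ccc([N+](=O)[O-])cc1` has not yet been measured. It differs from compound 3 in one place: 4-nitrophenyl in place of 3-methoxyphenyl on a saturated chain carbon bound to an oxygen on an unsaturated carbon. The entering 4-nitrophenyl is the group that compound 2 carries, while the rest of compound 4 matches compound 1.

The account therefore expects an upward step beyond the scatter, a number 51.2 percentage points higher from compound 3 to compound 4 (beyond the scatter), because compound 2 with its 4-nitrophenyl gives 18.4% in this assay and compound 1 gives 5.8%. Compound 4 is accordingly expected to give about 10%, with a likely range from -15% to 35%.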

Compound 4, a percentage reported as inhibition, at one concentration (the size of the read-out at that concentration, not a potency): -2.8%
For compound 4 the middle estimate is 12.8 percentage points above the measured one, within the range that was stated.
By their numbers in this assay, from the lowest: compound 3; then compounds 4 and 1 (each within the scatter of the next); then compound 2.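

In this assay, 4-nitrophenyl in place of 3-methoxyphenyl on a saturated chain carbon bound to an oxygen on an unsaturated carbon gives a number 38.4 percentage points higher from compound 3 to compound 4 (beyond the scatter), the first single change read at this position, and it shows that the group carried there can move the number well beyond the scatter. Nitro in place of trifluoromethyl on an aromatic carbon gives a number 8.6 percentage points lower from compound 1 to compound 4 (within the scatter), so in this assay the two groups are not told apart, and the low number of compound 3 stands apart from both. Hydrogen in place of chloro on an aromatic carbon gives a number 21.2 percentage points lower from compound 2 to compound 4 (beyond the scatter), which shows that the number of compound 2 depends on its chloro as well as on its 4-nitrophenyl.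

Nothing measured here explains why any of these steps takes the size it does. Still open, going by these compounds, is what an amine in place of the nitro on an aromatic carbon would give, and whether the low number of compound 3 is tied to the methoxy group itself or to where it sits on the ring.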